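Chloro removal on the shared core of compound 3

The source may hold more compounds than are shown below. What is called first, only, known or untested is meant among the compounds shown, and "the series" means these compounds.

In a functional assay on NCI-H23 cells (Homo sapiens) for cytotoxicity, read by sulforhodamine B assay, with a stated time of 48 h (a lower number here means a stronger inhibitor of growth, a higher number a weaker inhibitor of growth), compound 1 `ClCc1ccc(Cn2cnc3c(Cl)ncnc32)cc1` gives 660 nM, compound 2 `ClCc1cccc(Cn2cnc3c(Cl)nc(Cl)nc32)c1` gives 2130 nM and compound 3 `ClCc1ccccc1Cn1cnc2nc(Cl)nc(Cl)c21` gives 19100 nM. Compound 3 stands highest of the three in this assay, beyond the scatter from compound 2 and further still from compound 1. Compound 4 `ClCc1ccccc1Cn1cnc2ncnc(Cl)c21` is not yet measured; it differs from compound 3 by hydrogen in place of chloro on an aromatic carbon. Among the compounds with values here, no pair of measured compounds differs in one place alone, so the weight of this change has not been isolated: compound 1 lacks this chloro while compound 2 and compound 3 carry it, but the benzyl attachment also shifts across the three. The step from compound 3 to compound 4 is expected to be modest, toward a lower number, as a 2.1-fold lower number from compound 3 to compound 4 (0.33 log units; beyond the scatter). Compound 4 is accordingly estimated at 9000 nM, within 2500 nM to 30000 nM.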

Compound 4, concentration for 50% growth inhibition: 5010 nM
The estimate for compound 4 lay 1.8-fold (0.25 log units) above the measured number; the range from low to high includes it.
By their numbers in this assay, from the lowest: compound 1; then compound 2; then compound 4; then compound 3.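

Within the data shown here, this is the first pair that differs in one place alone. In this assay, hydrogen in place of chloro on the aromatic carbon between two ring nitrogen atoms gives a 3.8-fold lower number from compound 3 to compound 4 (0.58 log units; beyond the scatter), so with the benzyl attachment of compound 3 held fixed, growth inhibition does not depend on this chloro. Nothing measured here accounts for the size of this step.

Still open, from the compounds shown here alone, is whether an amine, a methoxy group or a methyl group on this carbon would give a lower number than hydrogen. Also open, going by these compounds, is whether the same change on compound 2 gives a step of similar size.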